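Shortening the tether in a weak monoamine oxidase A series

The source may report more compounds than this note shows. Statements on the series, on what has been measured and on what is new or still open speak of the compounds shown alone.

Compound 1 `Cn1c(=O)c2c(nc(SCCc3ccc(Br)cc3)n2C)n(C)c1=O` is the more closely watched of two measured analogues. In an assay on microsomes for inhibition of Amine oxidase [flavin-containing] A (Homo sapiens), read by fluorescence and spectrophotometry, with a stated time of 20 min (on this read-out lower numbers stand for stronger inhibition and higher numbers for weaker inhibition), compound 1 gives 108000 nM, the lower of the two numbers recorded so far. Compound 2 `COc1ccc(CCSc2nc3c(c(=O)n(C)c(=O)n3C)n2C)cc1` carries a methoxy in place of bromo on an aromatic carbon, and in this assay compound 2 gives 168000 nM; the step of a 1.6-fold higher number from compound 1 to compound 2 (0.19 log units; within the scatter) stays within the scatter, so the two compounds cannot be ranked. Compound 3 `Cn1c(=O)c2c(nc(SCc3cccc(Cl)c3)n2C)n(C)c1=O` has not been measured. It differs from compound 1 by 3-chlorophenyl in place of 4-bromobenzyl on a saturated chain carbon bound to a sulfur. Going by the values given here, no measured step touches this part of the molecule, so the only guide is that both compounds 1 and 2 sit at similar, weak values. Compound 3 is therefore expected to give about 130000 nM, in a range from 40000 nM to 400000 nM. That estimate corresponds to an expected step of a 1.2-fold higher number from compound 1 to compound 3 (0.08 log units; within the scatter), with wide uncertainty.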

Compound 3, half-maximal inhibitory concentration: 6430 nM
Beside the measured number, compound 3's estimate is 20-fold (1.31 log units) above it; measured number below the stated range.
By their numbers in this assay, from the lowest: compound 3; then compounds 1 and 2 (each within the scatter of the next).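

In this assay, 3-chlorophenyl in place of 4-bromobenzyl on a saturated chain carbon bound to a sulfur gives a 17-fold lower number from compound 1 to compound 3 (1.23 log units; beyond the scatter). Going by these compounds alone, this place in the molecule therefore responds strongly to change, which the only earlier step, methoxy in place of bromo on an aromatic carbon at a 1.6-fold higher number from compound 1 to compound 2 (0.19 log units; within the scatter), did not reveal. No measured evidence bears on the origin of this large step.

The replacement alters the halogen, its place on the ring and the chain in one move, so the step can be read only for the change as a whole. From the compounds shown here alone, what 4-bromophenyl, 3-chlorobenzyl or an unsubstituted phenyl would give at this place remains open, and with it which part of the change carries the step.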